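Notes on a second bromo substituent

This account rests on a few compounds, and the source may have more. Where it says the series, first, only, none or still open, it means among the compounds named here.

Compound 1 `OCc1cccc(C2=NCCCC2)c1`, compound 2 `Brc1cccc(C2=NCCCC2)c1` and compound 3 `Fc1cccc(C2=NCCCC2)c1` share one core and differ only in a single group on an aromatic carbon. In an assay on cell membranes for displacement of a labelled ligand from Neuronal acetylcholine receptor; alpha4/beta2 (Rattus norvegicus), read by radioligand binding, with a stated time of 30 min (a lower number here means a stronger inhibitor, a higher number a weaker inhibitor), compound 1 gives 35000 nM, compound 2 gives 5020 nM and compound 3 gives 2040 nM. Compound 2 therefore stands second highest of the three numbers, nearest to compound 3 and furthest from compound 1. The measured steps are a 7.0-fold lower number from compound 1 to compound 2 (0.84 log units; beyond the scatter), a 17-fold lower number from compound 1 to compound 3 (1.23 log units; beyond the scatter) and a 2.5-fold lower number from compound 2 to compound 3 (0.39 log units; beyond the scatter); each exchanges one group for another on an aromatic carbon, and none keeps a group while adding a second one.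

Compound 4 `Brc1cc(Br)cc(C2=NCCCC2)c1` keeps the bromo of compound 2 and differs from it by bromo in place of hydrogen on an aromatic carbon of a six-membered aromatic ring of carbon only, meta to a bromo group and meta to a group of 6 heavy atoms. Among the measured compounds shown here, no measured step bears directly on this change; the three steps only show that a single group changes this assay by modest to large amounts. For compound 4 the expectation is therefore a step in this assay that stays within the scatter or is at most modest, direction uncertain, leaning towards a higher number. The expected step is a 1.4-fold higher number from compound 2 to compound 4 (0.14 log units; within the scatter). Compound 4 is estimated at 7000 nM, with a range from 1800 nM to 28000 nM.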

Compound 4, inhibition constant: 18800 nM
For compound 4 the middle estimate is 2.7-fold (0.43 log units) below the measured one; the range from low to high includes it.
By their numbers in this assay, from the lowest: compound 3; then compound 2; then compounds 4 and 1 (each within the scatter of the next).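

In this assay, among the compounds shown here, a 3.7-fold higher number from compound 2 to compound 4 (0.57 log units; beyond the scatter) is the first step that keeps a group and adds a second one, and it runs towards a weaker inhibitor by an amount beyond the scatter. For the compounds shown here, the aromatic carbon meta to a bromo group and meta to a group of 6 heavy atoms is thus not indifferent to substitution: bromo in place of hydrogen there costs binding strength, whereas the earlier steps showed only what exchanging one group for another does at a single carbon. No measurement among the data shown speaks to the reason for this step.

On these data alone, whether the step belongs to bromo itself or to any group on this carbon stays open, and fluoro, an amine or a methoxy group at the same place on compound 2 would separate those two readings. Also open, as far as these compounds go, is whether a second group here moves the number in the same direction when the first group is the fluoro of compound 3 or the hydroxymethyl of compound 1 rather than the bromo of compound 2.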